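The source may hold more compounds than are shown below. What is called first, only, known or untested is meant among the compounds shown, and "the series" means these compounds.

Of the compounds shown here, two sharing one core have been read so far in a functional assay on MCF7 cells (Homo sapiens) for cytotoxicity, read by MTT assay, with a stated time of 72 h; on this read-out lower numbers stand for stronger inhibition and higher numbers for weaker inhibition. Compound 1 `O=C1c2c[n+]([O-])c3ccccc3c2C(=O)c2c1c1ccccc1n2Cc1cn(C[C@H](O)CO)nn1` gives > 1000 nM, which is a limit of the assay and not a number. Among the compounds with values here, compound 2 `CC1(C)O[C@@H](CO)[C@H](Cn2cc(Cn3c4c(c5ccccc53)C(=O)c3c[n+]([O-])c5ccccc5c3C4=O)nn2)O1` gives 690 nM, the only true number so far. Within the data shown here, the single measured step, an at least 1.4-fold lower number from compound 1 to compound 2 (0.16 log units; that floor lies within the scatter), puts 5-(hydroxymethyl)-2,2-dimethyl-1,3-dioxolan-4-yl in place of 1,2-dihydroxyethyl on a saturated chain carbon bound to an aromatic nitrogen.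

Compound 3 `O=C1c2c[n+]([O-])c3ccccc3c2C(=O)c2c1c1ccccc1n2Cc1cn([C@@H]2O[C@H](CO)[C@@H](O)[C@H](O)[C@H]2O)nn1` has not yet been measured. It differs from compound 2 by 3,4,5-trihydroxy-6-(hydroxymethyl)oxan-2-yl in place of (5-(hydroxymethyl)-2,2-dimethyl-1,3-dioxolan-4-yl)methyl on an aromatic nitrogen, with 3,4,5-trihydroxy-6-(hydroxymethyl)oxan-2-yl in place of (5-(hydroxymethyl)-2,2-dimethyl-1,3-dioxolan-4-yl)methyl on an aromatic nitrogen. Among the measured compounds shown here, only that one step bears on this change, and only loosely. Compound 1, whose 1,2-dihydroxyethyl group also carries free hydroxyl groups, stands at > 1000 nM, again a limit, so weaker inhibition and a higher number are expected for compound 3. The expected change is a 2.2-fold higher number from compound 2 to compound 3 (0.34 log units; beyond the scatter), though its size remains uncertain. Compound 3 is estimated at 1500 nM, with an expected range from 600 nM to 5000 nM.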

Compound 3, half-maximal inhibitory concentration: 590 nM
Compound 3: the middle estimate sits 2.5-fold (0.41 log units) above what was measured; measured number below the stated range.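

In this assay, putting 3,4,5-trihydroxy-6-(hydroxymethyl)oxan-2-yl in place of (5-(hydroxymethyl)-2,2-dimethyl-1,3-dioxolan-4-yl)methyl on an aromatic nitrogen of the five-membered aromatic ring with 3 nitrogen is a 1.2-fold lower number from compound 2 to compound 3 (0.07 log units; within the scatter), so a group with 4 hydrogen-bond donors and one with 1 hydrogen-bond donor cannot be told apart at this position. Against the 2,3-dihydroxypropyl group the step is an at least 1.6-fold lower number from compound 1 to compound 3 (0.22 log units; that floor lies within the scatter), which sets no order between the two groups, yet compound 3 shows that free hydroxyl groups at this position can go with a true number, 590 nM. Compound 1 remains a limit and not a number: the limit of > 1000 nM in this assay, at which 1 of the 3 values shown sits.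

From the compounds shown here alone, the true size of the step from the 2,3-dihydroxypropyl group therefore stays open. Also open, going by these compounds, is whether an amine, a carboxylic acid or a longer chain on this aromatic nitrogen would read the same in this assay as the two groups that gave true numbers.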